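The source may report more compounds than this note shows. Statements on the series, on what has been measured and on what is new or still open speak of the compounds shown alone.

Measured in a functional assay on HT-29 cells (Homo sapiens) for inhibition, with a stated time of 72 h; a higher number here means a weaker inhibitor, a lower number a stronger inhibitor:
- compound 1 `COc1ccc(S(=O)(=O)N2CCc3cccc(-c4ccc(F)nc4)c32)cc1`: 109 nM
- compound 2 `COc1ccc(S(=O)(=O)N2CCc3cccc(-c4ccc(N(C)C)cc4)c32)cc1`: 467 nM

Of these two, compound 2 has the higher number, 467 nM. Compound 3 `COc1ccc(S(=O)(=O)N2CCc3cccc(-c4cccc(F)c4)c32)cc1` differs from it as follows: 3-fluorophenyl in place of 4-(dimethylamino)phenyl on an aromatic carbon. For the measured compounds named here, the only measured step at this place is a 4.3-fold higher number from compound 1 to compound 2 (0.63 log units; beyond the scatter), and it introduced the same 4-(dimethylamino)phenyl that compound 3 gives up. On these data alone, a move back toward compound 1 at 109 nM is therefore expected, although 3-fluorophenyl itself is untested. The expected change is a 2.9-fold lower number from compound 2 to compound 3 (0.47 log units; beyond the scatter). For compound 3 the estimated value is 160 nM, with an expected range of 60 nM to 400 nM.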

Compound 3, half-maximal inhibitory concentration: 119 nM
Estimate against measurement, compound 3: 1.3-fold (0.13 log units) above; measured number inside the range.
By their numbers in this assay, from the lowest: compounds 1 and 3 (each within the scatter of the next); then compound 2.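

In this assay, 3-fluorophenyl in place of 4-(dimethylamino)phenyl gives a 3.9-fold lower number from compound 2 to compound 3 (0.59 log units; beyond the scatter), so the lower number of compound 1 is not unique to 6-fluoropyridin-3-yl. The comparison with that group shows a 1.1-fold higher number from compound 1 to compound 3 (0.04 log units; within the scatter), which leaves the two groups unseparated and shows that the ring nitrogen of 6-fluoropyridin-3-yl is not required at this position. Nothing available explains the difference between these groups.

On these data alone, whether a primary amine or a morpholine would raise the number as 4-(dimethylamino)phenyl does remains open. So does the effect of an unsubstituted phenyl at this position.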